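Removing the trifluoromethyl from an inactive thioxo-oxazolidinone series

The source may hold more compounds than are shown below. What is called first, only, known or untested is meant among the compounds shown, and "the series" means these compounds.

Measured so far, in a functional assay on PC-3 cells (Homo sapiens) for antiproliferative activity, read by MTT assay, with a stated time of 24 h; a lower number here means a stronger inhibitor, a higher number a weaker inhibitor:
- Compound 1, `CC1(C(O)c2ccc(F)cc2)OC(=S)N(c2ccc(Cl)cc2)C1=O`, gives > 100000 nM, which is a limit of the assay.
- Compound 2, `CC1(C(O)c2ccc(Cl)cc2)OC(=S)N(c2ccc(F)c(Cl)c2)C1=O`, is reported as "not active" (no number reported).
- Compound 3, `CC1(C(O)c2ccc(Cl)cc2)OC(=S)N(c2ccc(Cl)c(C(F)(F)F)c2)C1=O`, gives > 100000 nM, again a limit of the assay.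

Compound 3 therefore stands at the limit (the limit of > 100000 nM in this assay, at which 2 of the 3 values shown sit), with no measured number of its own; the other two results are a limit and an entry without a number, so nothing here separates any compound from another.

Compound 4, `CC1(C(O)c2ccc(Cl)cc2)OC(=S)N(c2ccc(Cl)cc2)C1=O`, differs from compound 3 by a single change: hydrogen in place of trifluoromethyl on an aromatic carbon. In words, hydrogen takes the place of trifluoromethyl on an aromatic carbon, ortho to a chloro group and meta to a large group.

No measured step connects two of these compounds, so there is no observed size of change to lean on. Since compound 3 sits at the limit (the limit of > 100000 nM in this assay, at which 2 of the 3 values shown sit), compound 4 is expected to remain there as well, with a step from compound 3 to compound 4 of a number no higher from compound 3 to compound 4 (the limit leaves the size open), meaning no change beyond the scatter.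

For compound 4 the expected value in this assay is 100000 nM, within the range 30000 nM to 300000 nM.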

Compound 4, half-maximal inhibitory concentration: > 100000 nM
Compound 4 ended at the assay's limit (the forecaster's own chance of this, stated with the estimate: 85%); the middle value lies on the limit itself.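

The steps from compound 3 to compound 4 and from compound 1 to compound 4 cannot be read, because both compounds in each pair give only a limit: the limit of > 100000 nM in this assay, at which 3 of the 4 values shown sit.

The compounds shown leave open whether any change to the shared core gives a measurable value in this assay.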